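Chloro-aryl acetal series: cytotoxicity on HEL cells

The source may hold more compounds than are shown below. What is called first, only, known or untested is meant among the compounds shown, and "the series" means these compounds.

Measured compounds:
compound 1, `CO[C@@H]1[C@@H](OC)[C@H](c2ccccc2)O[C@@H]2CO[C@@H](c3ccco3)O[C@@H]12`, "not determined" (no result reported)
compound 2, `CO[C@@H]1[C@@H](OC)[C@H](c2ccccc2)O[C@@H]2CO[C@@H](c3ccc(Cl)cc3)O[C@@H]12`, >= 100 ug/mL

In a functional assay on HEL cells (Homo sapiens) for cytotoxicity (a higher number here means that more compound is tolerated, a lower number that less compound is tolerated), compound 2 reaches only a limit of the assay, >= 100 ug/mL; see (the limit of >= 100 ug/mL in this assay, at which 1 of the 2 values shown sits). For compound 1, `CO[C@@H]1[C@@H](OC)[C@H](c2ccccc2)O[C@@H]2CO[C@@H](c3ccco3)O[C@@H]12`, no result was reported. Compound 3, `CO[C@@H]1[C@@H](OC)[C@H](c2ccccc2)O[C@@H]2CO[C@@H](c3cccc(Cl)c3)O[C@@H]12`, differs from compound 2 by 3-chlorophenyl in place of 4-chlorophenyl on a saturated ring carbon. For the measured compounds named here, no measured step exists, so no direction is known; the expectation is a step of a number no higher from compound 2 to compound 3 (the limit leaves the size open), none beyond the scatter, in this assay. Compound 3 is expected at 100 ug/mL, between 50 ug/mL and 200 ug/mL.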

Compound 3, minimum cytotoxic concentration: >= 40 ug/mL
Compound 3: only a limit was reported; the forecaster's own chance of this, stated with the estimate: 75%; the middle value does not contradict the limit.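

In this assay compound 2 gives only a limit, >= 100 ug/mL. Compound 3 also gives only a limit, >= 40 ug/mL. No step can be read between compound 2 and compound 3. Still open, from the compounds shown here alone, is whether 3-chlorophenyl in place of 4-chlorophenyl changes the tolerated concentration at all.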